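Swapping an Ester Group for a Methyl Group

A few compounds are considered here, and "the series" means these few. Any claim that something is new, unique, unknown or untested is made for them only; others in the source may bear on it.

In a functional assay on SK-BR-3 cells (Homo sapiens) (a higher number here means a weaker inhibitor, a lower number a stronger inhibitor), compound 1 `Cn1cc(-c2nc(C(N)=O)cs2)c2c1C(=O)C=C(N)C2=O` gives 8700 nM. Compound 2 `CCOC(=O)c1csc(-c2cn(C)c3c2C(=O)C(OC)=CC3=O)n1` gives 27800 nM, the higher of the two numbers, which makes it the weaker inhibitor by a gap beyond the usual scatter of repeat measurements. Compound 3 `COC1=CC(=O)c2c(c(-c3nc(C)cs3)cn2C)C1=O` keeps the core of compound 2 but has methyl in place of ethoxycarbonyl on an aromatic carbon. For the measured compounds named here, no measured pair shows this exact change, so any forecast is loose. Going by the values given here, the only lower number available is that of compound 1 at 8700 nM, which also lacks the ethoxycarbonyl but differs in other places too. A small move toward stronger inhibition in this assay is therefore expected, about the size of the scatter, and the estimated step is a 1.9-fold lower number from compound 2 to compound 3 (0.27 log units; within the scatter). For compound 3 the estimated value is 15000 nM, with an expected range from 4000 nM to 45000 nM.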

Compound 3, half-maximal inhibitory concentration: 1400 nM
Compound 3: the middle estimate sits 11-fold (1.03 log units) above what was measured, outside the stated range (below it).
By their numbers in this assay, from the lowest: compound 3; then compound 1; then compound 2.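

This aromatic carbon, two ring bonds from the ring sulfur, turns out to be highly sensitive to what it carries: methyl in place of ethoxycarbonyl gives a 20-fold lower number from compound 2 to compound 3 (1.30 log units; beyond the scatter) in this assay and is a large step. For the compounds shown here, the earlier compounds had no pair differing at this one place, so this is the first clean reading of the position, and it shows that the ethoxycarbonyl is not required for inhibition on this core. Nothing available accounts for the size of this step.

The compounds shown leave open whether the gain comes from methyl itself or simply from losing the ester, a question that a bare hydrogen, an ethyl group or a carboxylic acid on this carbon could help settle. Also open, going by these compounds, is whether methyl would give a step of similar size on the core of compound 1.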